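Dropping the nitro group from compound 2

The source may hold more compounds than are shown below. What is called first, only, known or untested is meant among the compounds shown, and "the series" means these compounds.

Compounds measured so far:
compound 1, `O=C(O)CCc1ccc(C#Cc2ccnc(Oc3ccccc3)c2)cc1`, 479 nM
compound 2, `O=C(O)CCc1ccc(C#Cc2ncccc2[N+](=O)[O-])cc1`, 11000 nM
compound 3, `O=C(O)CCc1ccc(C#Cc2ccc(Cl)nc2)cc1`, 708 nM

Three compounds share the same acid-bearing core and differ only in what decorates the pyridine ring at the far end. In an in vitro functional assay on 1321-N1 cells for agonist activity at Free fatty acid receptor 1 (Homo sapiens), read by fluorescence, spectrophotometry and calcium flux (on this read-out lower numbers stand for an effect already at smaller amounts and higher numbers for an effect only at larger amounts of compound), compound 2 gives 11000 nM, the highest of the three numbers; the gaps to compound 3 at 708 nM and to compound 1 at 479 nM both lie beyond the usual scatter, so compound 2 is the least active of the set.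

Compound 4, `O=C(O)CCc1ccc(C#Cc2ccccn2)cc1`, has not yet been measured. It differs from compound 2 in one place: hydrogen in place of nitro on an aromatic carbon. The pyridine ring of compound 4 therefore carries nothing at all, while compound 1 and compound 3 each carry a substituent and both sit far lower than compound 2.

Going by the values given here, with no measured pair showing this exact change, the expectation is that removing the nitro group moves compound 4 toward the region where compound 1 and compound 3 sit, a step of a 7.3-fold lower number from compound 2 to compound 4 (0.87 log units; beyond the scatter) in this assay. Compound 4 is estimated at 1500 nM, within a range from 400 nM to 6000 nM.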

Compound 4, half-maximal effective concentration: 13200 nM
The estimate for compound 4 lay 8.8-fold (0.94 log units) below the measured number, outside the stated range (above it).
By their numbers in this assay, from the lowest: compounds 1 and 3 (each within the scatter of the next); then compounds 2 and 4 (each within the scatter of the next).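

In this assay, putting hydrogen in place of the nitro group gives a 1.2-fold higher number from compound 2 to compound 4 (0.08 log units; within the scatter) and so leaves the two compounds indistinguishable on this read-out. On this aromatic carbon, two atoms from the ring nitrogen and ortho to a large group, having a nitro group or only hydrogen therefore makes no difference that the measurement can resolve. The available data offer no explanation for this result.

From the compounds shown here alone, what remains open is whether this place is indifferent to every group or only to these two: an amine, a methoxy group or a chlorine on the same carbon could still move the number in either direction. Going by these compounds, it is also open whether a nitro group would be equally without consequence on another carbon of the same ring.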